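Chloro Substitution on the Aromatic Ring: Compound 2 to Compound 3

A few compounds are considered here, and "the series" means these few. Any claim that something is new, unique, unknown or untested is made for them only; others in the source may bear on it.

The series rests on a shared core, seen in compound 1 `Cc1c(/N=C/c2ccccc2)c(=O)n(-c2ccccc2)n1C` and compound 2 `Cc1c(/N=C/c2ccc(Cl)cc2)c(=O)n(-c2ccccc2)n1C`. Going by the values given here, in a functional assay on HT-29 cells (Homo sapiens) for cytotoxicity, read by MTT assay, with a stated time of 72 h (on this read-out higher numbers stand for weaker inhibition and lower numbers for stronger inhibition), compound 1 gives 851000000 nM, while compound 2 gives 309000000 nM; compound 2 thus holds the lowest of the two numbers so far, with compound 1 as its nearest neighbour. Among the compounds with values here, the single measured step, a 2.8-fold lower number from compound 1 to compound 2 (0.44 log units; beyond the scatter), lies beyond the scatter.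

Compound 3 `Cc1c(/N=C/c2ccc(Cl)cc2Cl)c(=O)n(-c2ccccc2)n1C` differs from compound 2 by chloro in place of hydrogen on an aromatic carbon. Within the data shown here, the only step that bears on this change is a 2.8-fold lower number from compound 1 to compound 2 (0.44 log units; beyond the scatter), likewise chloro in place of hydrogen on that ring. Among the measured compounds shown here, a step of similar kind, or a somewhat smaller one, toward a lower number is therefore expected, with the caveat that no measured pair shows a chloro entering at this place. Compound 3 is expected to give about 180000000 nM in this assay, within 60000000 nM to 450000000 nM. The expected step is a 1.7-fold lower number from compound 2 to compound 3 (0.23 log units; within the scatter).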

Compound 3, half-maximal inhibitory concentration: 178000000 nM
Compound 3: middle estimate off by 1.0-fold (0.00 log units), on the high side; the measured number falls inside the stated range.
By their numbers in this assay, from the lowest: compounds 3 and 2 (each within the scatter of the next); then compound 1.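

In this assay, the second chloro, ortho to a large group and meta to a chloro group, gives a 1.7-fold lower number from compound 2 to compound 3 (0.24 log units; within the scatter), so the change from 4-chlorophenyl to 2,4-dichlorophenyl cannot be separated from assay noise. Only the full replacement of phenyl by 2,4-dichlorophenyl clears the scatter, with a 4.8-fold lower number from compound 1 to compound 3 (0.68 log units; beyond the scatter), and that step spans both chloro groups at once. No measurement on hand bears on the reason for either step.

A chloro at this place on an otherwise unsubstituted phenyl would show whether its step depends on the chloro already on the ring. Also open, going by these compounds, is how a methoxy group, an amine or a carboxylic acid at the same place would read.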